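Ethyl for methyl on the amine of two chromene isomers

A few compounds are considered here, and "the series" means these few. Any claim that something is new, unique, unknown or untested is made for them only; others in the source may bear on it.

The study compares two cores that carry the same side chain. Compound 1 `CNCC(=O)Nc1cc(OC)ccc1C(=O)c1ccc(OC)c2c1OC(C)(C)C=C2` and compound 2 `CNCC(=O)Nc1cc(OC)ccc1C(=O)c1ccc(OC)c2c1C=CC(C)(C)O2` are built from the same atoms joined differently; the difference between the two cores is not broken down here. In a functional assay on MCF7 cells (Homo sapiens) for antiproliferative activity, read by MTT assay, with a stated time of 48 h (on this read-out higher numbers stand for weaker inhibition and lower numbers for stronger inhibition), compound 1 gives 820 nM, while compound 2 gives 3040 nM. Compound 3 `CCNCC(=O)Nc1cc(OC)ccc1C(=O)c1ccc(OC)c2c1OC(C)(C)C=C2` differs from compound 1 by methyl in place of hydrogen on a saturated chain carbon bound to an amine nitrogen; in this assay compound 3 gives 5200 nM, and the step of a 6.3-fold higher number from compound 1 to compound 3 (0.80 log units; beyond the scatter) is a modest weakening.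

Compound 4 `CCNCC(=O)Nc1cc(OC)ccc1C(=O)c1ccc(OC)c2c1C=CC(C)(C)O2` carries the same change on the core of compound 2, (methyl in place of hydrogen on a saturated chain carbon bound to an amine nitrogen), at the same place. Because the step of a 6.3-fold higher number from compound 1 to compound 3 (0.80 log units; beyond the scatter) went toward a higher number on the core of compound 1, the same direction is expected on the core of compound 2, and the step from compound 2 to compound 4 is estimated at a 4.6-fold higher number from compound 2 to compound 4 (0.66 log units; beyond the scatter) in this assay. This rests on a single measured pair, so the expectation is held loosely. For compound 4 the estimate in this assay is 14000 nM, with a range expected from 4500 nM to 45000 nM.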

Compound 4, half-maximal inhibitory concentration: 7230 nM
The estimate for compound 4 lay 1.9-fold (0.29 log units) above the measured number; the measured number falls inside the stated range.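

On the core of compound 2 the change from methylamino to ethylamino again goes toward weaker inhibition in this assay, with a 2.4-fold higher number from compound 2 to compound 4 (0.38 log units; beyond the scatter), so the direction seen on the core of compound 1 carries over to this second core. The size of the step does not carry over unchanged, and the two cores part on this point: the same change on two cores in this assay, a 6.3-fold higher number (0.80 log units; beyond the scatter) from compound 1 to compound 3 and a 2.4-fold higher number (0.38 log units; beyond the scatter) from compound 2 to compound 4, 2.7-fold (0.43 log units) apart, beyond the scatter of two such steps. Within the data shown here, with only one pair on each core, this shows a shared direction for this one change, but it does not show why the step differs in size or whether any other change at this place would behave alike.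

The compounds shown stop at methylamino and ethylamino, which leaves open how a longer chain such as propyl, a branched isopropyl or a ring amine such as pyrrolidine would fare on either core. They also leave open how the unsubstituted primary amine would compare on the two cores.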